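A few compounds are considered here, and "the series" means these few. Any claim that something is new, unique, unknown or untested is made for them only; others in the source may bear on it.

Working notes on a small series sharing one core. In a functional assay on A-431 cells (Homo sapiens) for antiproliferative activity, read by MTT assay, with a stated time of 24 h (a lower number here means a stronger inhibitor, a higher number a weaker inhibitor), compound 1 (`Cc1cc(=O)n2nc(SCc3ccc(C(C)C)cc3)nc2[nH]1`) gives 17300 nM and compound 2 (`Cc1cc(=O)n2nc(SCc3cccc(C(F)(F)F)c3)nc2[nH]1`) gives 21800 nM. Going by the values given here, these two numbers lie within the scatter of each other, which leaves compound 1 level with the only other measured member of the series.

Still unmeasured is compound 3 (`Cc1cc(=O)n2nc(SCc3ccc([N+](=O)[O-])cc3)nc2[nH]1`). It differs from compound 1 by nitro in place of isopropyl on an aromatic carbon, para to a large group: nitro in place of isopropyl on an aromatic carbon. Among the compounds with values here, no measured pair isolates a single change, and the series offers no step against which to scale this one. Within the data shown here, the only guide is that compound 1 at 17300 nM and compound 2 at 21800 nM carry different groups on the aromatic ring and still give values within the scatter. On that thin basis, no shift beyond the scatter is expected in this assay, in either direction. The estimated step is a 1.2-fold higher number from compound 1 to compound 3 (0.06 log units; within the scatter). In this assay, compound 3 is estimated at 20000 nM, with an expected range from 9000 nM to 45000 nM.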

Compound 3, half-maximal inhibitory concentration: > 40000 nM
Compound 3: only a limit was reported (the forecaster's own chance of this, stated with the estimate: 10%); middle value at least 2.0-fold (0.30 log units) from the limit.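

In this assay, this aromatic carbon, para to a large group, does not tolerate every substituent equally: nitro in place of isopropyl gives an at least 2.3-fold higher number from compound 1 to compound 3 (0.36 log units; beyond the scatter). Compound 3 gives > 40000 nM, which is a limit of the assay and not a number. This is the only step in the series that isolates a single change, and its true size remains unknown, as it rests on a bound rather than on two measured numbers: the limit of > 40000 nM in this assay, at which 1 of the 3 values shown sits.

The pair alone cannot show which difference between isopropyl and nitro accounts for the step, whether the change of atoms, the added double bond outside the aromatic ring or the hydrogen-bond acceptors that enter with nitro, nor how far compound 3 lies beyond its limit. From the compounds shown here alone, it also remains open whether an amine, a methoxy group or a carboxylic acid on the same aromatic carbon would give a number level with compound 1 or one that reaches the limit seen for compound 3.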